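A few compounds are considered here, and "the series" means these few. Any claim that something is new, unique, unknown or untested is made for them only; others in the source may bear on it.

Working notes on the series.

Compound 1 `COc1ccc(C2=C(c3ccc(SC)cc3)CC3CCCN3C2=O)cc1O` gives 6000 nM in a functional assay on DU-145 cells (Homo sapiens) for cytotoxicity; a lower number here means a stronger inhibitor of growth, a higher number a weaker inhibitor of growth. Compound 2 `CSc1ccc(C2=C(c3ccc(O)c(O)c3)C(=O)N3CCCC3C2)cc1` gives 60000 nM in this assay. The change between them, (hydrogen in place of methyl on an oxygen on an aromatic ring), made the step of a 10-fold higher number from compound 1 to compound 2 (1.00 log units; beyond the scatter). Compound 3 `COc1ccc(C2=C(c3ccc(SC)cc3)CC3CCCN3C2=O)cc1` gives 900 nM in this assay, the lowest number of the three measured compounds.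

Compound 4 `CSc1ccc(C2=C(c3ccc(O)cc3)C(=O)N3CCCC3C2)cc1` is not yet measured. It differs from compound 3 by hydrogen in place of methyl on an oxygen on an aromatic ring, the same change as that from compound 1 to compound 2. The cores of compound 1 and compound 3 differ by hydrogen in place of hydroxy on an aromatic carbon. Because the earlier change gave a 10-fold higher number from compound 1 to compound 2 (1.00 log units; beyond the scatter), a step of similar size is expected from compound 3 to compound 4, namely a 7.8-fold higher number from compound 3 to compound 4 (0.89 log units; beyond the scatter). On that basis compound 4 is estimated at 7000 nM in this assay, with an expected range from 2500 nM to 25000 nM.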

Compound 4, concentration for 50% growth inhibition: > 100000 nM
Compound 4: no number, only a limit; the forecaster's own chance of this, stated with the estimate: 5%; middle value at least 14-fold (1.15 log units) from the limit.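

In this assay, from the compounds shown here alone, compound 4 gives > 100000 nM, which is a limit of the assay and not a number, so the true size of each step into compound 4 stays unknown. Hydrogen in place of methyl on an oxygen on an aromatic ring does not carry over at one size, with an at least 110-fold higher number from compound 3 to compound 4 (2.04 log units; beyond the scatter) set against the earlier step: the same change on two cores in this assay, a 10-fold higher number (1.00 log units; beyond the scatter) from compound 1 to compound 2 and an at least 110-fold higher number (2.04 log units; beyond the scatter) from compound 3 to compound 4, at least 11-fold (1.04 log units) apart, beyond the scatter of two such steps

Replacing 3-hydroxy-4-methoxyphenyl with 4-hydroxyphenyl gives an at least 16-fold higher number from compound 1 to compound 4 (1.22 log units; beyond the scatter), while hydrogen in place of hydroxy on an aromatic carbon gives an at least 1.6-fold higher number from compound 2 to compound 4 (0.22 log units; that floor lies within the scatter), which also differs from the earlier step with that change: the same change on two cores in this assay, a 6.7-fold lower number (0.82 log units; beyond the scatter) from compound 1 to compound 3 and an at least 1.6-fold higher number (0.22 log units; that floor lies within the scatter) from compound 2 to compound 4, at least 11-fold (1.04 log units) apart, beyond the scatter of two such steps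

The compounds shown leave open how a longer chain on that oxygen, or an amine in place of the methoxy, would read. They also leave open whether either change would behave alike on any further core.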